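Pyrimidine for pyridine on a piperidinol amide

This account rests on a few compounds, and the source may have more. Where it says the series, first, only, none or still open, it means among the compounds named here.

Measured so far:
compound 1 `O=C(c1ccccc1-c1ccncc1)N1CCC(O)(Cc2ccccc2)CC1`: 7.9 nM
compound 2 `O=C(c1ccccc1-c1ccncn1)N1CCC(O)(Cc2ccccc2)CC1`: 4.3 nM
compound 3 `O=C(c1ccccc1-c1ccncc1)N1CCC(O)(Cc2ccccn2)CC1`: 21 nM

All three compounds were tested in an assay for inhibition of cholesterol 24-hydroxylase (Homo sapiens), using NADPH, with stated times of 15 min and 5 min; on this read-out higher numbers stand for weaker inhibition and lower numbers for stronger inhibition. Compound 3 gives the highest number of the three. Its nearest neighbour is compound 1, and the step of a 2.7-fold higher number from compound 1 to compound 3 (0.42 log units; beyond the scatter) lies beyond the scatter. Compound 2 stands furthest away: compound 2 gives 4.3 nM, while compound 3 gives 21 nM.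

Compound 4 `O=C(c1ccccc1-c1ccncn1)N1CCC(O)(Cc2ccccn2)CC1` is not yet measured. It differs from compound 3 in one place: pyrimidin-4-yl in place of pyridin-4-yl on an aromatic carbon. The same exchange has already been made once within this set, on an otherwise identical pair, and there it gave a 1.8-fold lower number from compound 1 to compound 2 (0.26 log units; within the scatter). That step stays within the scatter, so nothing beyond the scatter is expected from the same exchange here, although a somewhat lower number would fit the earlier pair. In this assay compound 4 is therefore expected to come out at 13 nM, with a range from 5 nM to 35 nM. This estimate amounts to an expected step of a 1.6-fold lower number from compound 3 to compound 4 (0.21 log units; within the scatter), a change that would still sit inside the usual scatter of repeated measurements.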

Compound 4, half-maximal inhibitory concentration: 36 nM
Estimate against measurement, compound 4: 2.8-fold (0.44 log units) below, and the stated range ends below it.
By their numbers in this assay, from the lowest: compounds 2 and 1 (each within the scatter of the next); then compounds 3 and 4 (each within the scatter of the next).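

The exchange of pyridin-4-yl for pyrimidin-4-yl gives a 1.7-fold higher number from compound 3 to compound 4 (0.23 log units; within the scatter) in this assay, so taken alone it is again a small step, as it was on the core of compound 1. What is new is that the exchange does not carry over unchanged from one core to the other, since the two small steps point in opposite directions and the gap between them exceeds what scatter would explain: the same change on two cores in this assay, a 1.8-fold lower number (0.26 log units; within the scatter) from compound 1 to compound 2 and a 1.7-fold higher number (0.23 log units; within the scatter) from compound 3 to compound 4, 3.1-fold (0.50 log units) apart, beyond the scatter of two such steps. The same coupling appears from the other side, where pyridin-2-yl in place of phenyl gives an 8.4-fold higher number from compound 2 to compound 4 (0.92 log units; beyond the scatter), a larger step with pyrimidin-4-yl on the aromatic ring than with pyridin-4-yl there: the same change on two cores in this assay, a 2.7-fold higher number (0.42 log units; beyond the scatter) from compound 1 to compound 3 and an 8.4-fold higher number (0.92 log units; beyond the scatter) from compound 2 to compound 4, 3.1-fold (0.50 log units) apart, beyond the scatter of two such steps.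

These compounds form a single square of two changes, so they cannot show whether the coupling extends to other groups at this place, such as pyridin-3-yl or a nitrile, or to other groups on the saturated chain carbon, such as pyridin-3-yl in place of pyridin-2-yl. Nor do they say what lies behind the coupling, which remains an observation from two pairs in one assay.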